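A few compounds are considered here, and "the series" means these few. Any claim that something is new, unique, unknown or untested is made for them only; others in the source may bear on it.

In a functional assay on THP-1 cells (Homo sapiens) for inhibition, read by sulforhodamine B assay, with a stated time of 48 h, tested at 50 uM (a higher number here means more inhibition of growth at the concentration tested, a lower number less inhibition of growth), compound 1 `COc1ccc(/C=C/C(=O)/C=C/c2ccc(OCc3cn(CCCCCOc4cc(=O)oc5ccccc45)nn3)c(OC)c2)cc1OC` gives 47%. That value lies within the usual scatter of compound 3 `COc1ccc(/C=C/C(=O)/C=C/c2ccc(OCc3cn(CCCOc4cc(=O)oc5ccccc45)nn3)c(OC)c2)cc1`, at 56%, while compound 2 `COc1cc(/C=C/C(=O)/C=C/c2ccccc2)ccc1OCc1cn(CCCCOc2cc(=O)oc3ccccc23)nn1`, at 36%, lies lower than compound 1, beyond the scatter. Compound 4 `COc1cc(/C=C/C(=O)/C=C/c2ccco2)ccc1OCc1cn(CCCCCOc2cc(=O)oc3ccccc23)nn1` has yet to be measured in this assay. Its structure departs from that of compound 1 by furan-2-yl in place of 3,4-dimethoxyphenyl on a double-bonded chain carbon bound to a double-bonded chain carbon, with furan-2-yl in place of 3,4-dimethoxyphenyl on a double-bonded chain carbon bound to a double-bonded chain carbon. Going by the values given here, no measured pair differs in this one place, so the data offer no direct guide. The expected change is small and downward, not clearly beyond the scatter: a number 5 percentage points lower from compound 1 to compound 4 (within the scatter). Compound 4 is estimated at 42%, with an expected range from 25% to 58%.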

Compound 4, percent growth inhibition at one concentration: 39%
Compound 4: the middle estimate sits 3 percentage points above what was measured; the range from low to high includes it.
By their numbers in this assay, from the lowest: compounds 2, 4, 1 and 3 (each within the scatter of the next, the first and the last beyond it).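

In this assay the first step read at this place, on a double-bonded chain carbon bound to a double-bonded chain carbon, is a number 8 percentage points lower from compound 1 to compound 4 (within the scatter) for furan-2-yl in place of 3,4-dimethoxyphenyl. The five-membered aromatic ring with 1 hetero atom thus cannot be told apart here from the six-membered aromatic ring of carbon only. Nothing given here accounts for this result. On these data alone, whether thiophen-2-yl or a pyridine ring at this place would give a number beyond the scatter stays open. A single step at one concentration also leaves open how far this place matters at all.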